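Fluoro in place of chloro on the phenyl of compound 2

The source may report more compounds than this note shows. Statements on the series, on what has been measured and on what is new or still open speak of the compounds shown alone.

Compound 1, `Fc1ccc(C2CC(c3ccc(Cl)s3)=NN2c2nc(-c3ccc(C(F)(F)F)cc3)cs2)cc1`, reached only the limit > 500 ug/mL in a functional assay on A549 cells (Homo sapiens) for antiproliferative activity, read by XTT assay, with a stated time of 24 h; on this read-out higher numbers stand for weaker inhibition and lower numbers for stronger inhibition.
Compound 2, `Fc1ccc(C2CC(c3ccc(Cl)s3)=NN2c2nc(-c3ccc(Cl)cc3)cs2)cc1`, gives 125 ug/mL in this assay.

Compound 2 holds the only number shown in this assay; the other value is a limit, not a number. Compound 3, `Fc1ccc(-c2csc(N3N=C(c4ccc(Cl)s4)CC3c3ccc(F)cc3)n2)cc1`, is still to be measured there. It differs from compound 2 in one place: fluoro in place of chloro on an aromatic carbon. The same difference, cut one bond further out, reads 4-chlorophenyl to 4-fluorophenyl.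

Going by the values given here, only one measured step exists, an at least 4.0-fold lower number from compound 1 to compound 2 (0.60 log units; beyond the scatter), and it changes the same six-membered ring by a different swap, chloro in place of trifluoromethyl; its size rests on (the limit of > 500 ug/mL in this assay, at which 1 of the 2 values shown sits). Among the compounds with values here, no measured pair shows fluoro against chloro, so the direction of the present change cannot be read from the data. Within the data shown here, the one step does show that a group on this ring can move the number. I therefore expect a step of a 1.6-fold higher number from compound 2 to compound 3 (0.20 log units; within the scatter), which may fall within the scatter. For compound 3 the estimate in this assay is 200 ug/mL, with a range from 60 ug/mL to 500 ug/mL.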

Compound 3, half-maximal inhibitory concentration: > 500 ug/mL
Compound 3 was reported as a limit; the forecaster's own chance of this, stated with the estimate: 25%; middle value at least 2.5-fold (0.39 log units) from the limit.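

In this assay, the exchange of chloro for fluoro on this six-membered ring now has a measured result, an at least 4.0-fold higher number from compound 2 to compound 3 (0.60 log units; beyond the scatter), and this step lies beyond the usual scatter. The earlier step, an at least 4.0-fold lower number from compound 1 to compound 2 (0.60 log units; beyond the scatter), showed only that replacing trifluoromethyl with chloro could lower the number; the new step shows that a small halogen swap at the same place can also move it, and in the direction of weaker inhibition. Among the three groups shown on this ring, chloro alone gives a number rather than a limit, so compound 2 is the only one of the three with a measurable value, and both of the other compounds lie on the weaker side of it.

Fluoro and trifluoromethyl cannot be ranked against each other, as the step between compound 1 and compound 3 cannot be read, and the series gives little room for finer comparison: the limit of > 500 ug/mL in this assay, at which 2 of the 3 values shown sit. It remains open whether bromo, methyl, methoxy or an amine on this ring would match compound 2 or lower the number further, and whether chloro would give the same gain elsewhere on the shared core.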